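Moving from an ester to an acid on the aniline nitrogen

The source may hold more compounds than are shown below. What is called first, only, known or untested is meant among the compounds shown, and "the series" means these compounds.

Going by the values given here, the three compounds measured so far share a core in which a benzyl sulfone is joined through a double bond to a methoxy-bearing aromatic ring. Compound 1 `COc1ccc(CS(=O)(=O)/C=C/c2c(OC)cccc2OC)cc1[N+](=O)[O-]` gives 20000 nM in a functional assay on K562 cells (Homo sapiens) for cytotoxicity, read by trypan blue exclusion, with a stated time of 96 h; a lower number here means a stronger inhibitor, a higher number a weaker inhibitor. Compound 2 `COc1cc(OC)c(/C=C/S(=O)(=O)Cc2ccc(OC)c([N+](=O)[O-])c2)c(OC)c1` gives 2500 nM in the same test, a change of an 8.0-fold lower number from compound 1 to compound 2 (0.90 log units; beyond the scatter). Compound 3 `COC(=O)C(Nc1cc(CS(=O)(=O)/C=C/c2c(OC)cc(OC)cc2OC)ccc1OC)c1ccccc1` gives 30 nM, the lowest of the three numbers, and its step from compound 2 was an 83-fold lower number from compound 2 to compound 3 (1.92 log units; beyond the scatter).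

Compound 4 `COc1ccc(C(Nc2cc(CS(=O)(=O)/C=C/c3c(OC)cc(OC)cc3OC)ccc2OC)C(=O)O)cc1` differs from compound 3 in one place: carboxy(4-methoxyphenyl)methyl in place of methoxycarbonyl)(benzyl on a nitrogen on an aromatic ring. Among the compounds with values here, no measured step involves a change of this kind. The step from compound 1 to compound 2 shows that adding a methoxy group on an aromatic carbon once gave a modest gain, and the step from compound 2 to compound 3 shows that the large substituent on the nitrogen matters, but neither tells how exchanging a methoxycarbonyl for a carboxy group behaves here. The expectation is therefore a step close to the scatter, with wide uncertainty, estimated as a 2.0-fold higher number from compound 3 to compound 4 (0.30 log units; within the scatter). Compound 4 is expected to give about 60 nM in this assay, within a range of 12 nM to 300 nM.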

Compound 4, half-maximal inhibitory concentration: 15 nM
Beside the measured number, compound 4's estimate is 4.0-fold (0.60 log units) above it; measured number inside the range.
By their numbers in this assay, from the lowest: compounds 4 and 3 (each within the scatter of the next); then compound 2; then compound 1.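

Exchanging methoxycarbonyl)(benzyl for carboxy(4-methoxyphenyl)methyl on a nitrogen on an aromatic ring gives a 2.0-fold lower number from compound 3 to compound 4 (0.30 log units; within the scatter) in this assay, so the two compounds cannot be told apart in this test. The earlier steps shown here showed only that a large substituent at this place can go with a much lower number; this step adds that the substituent can be rebuilt, with a free carboxy group replacing the ester and a hydrogen-bond donor that the leaving group lacks, and the number stays within the scatter. Nothing measured on these compounds offers a reason for this result.

Since the step changes the ester and the ring substituent together, the compounds shown leave open what each change does alone, and how a carboxy group with an unsubstituted phenyl ring, or a methoxycarbonyl group with a 4-methoxyphenyl ring, would behave. They also leave open whether other groups can stand in place of the carboxy group at this position, such as a primary amide or a hydroxymethyl group.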